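Replacing oxan-4-yl with 3,3-difluorocyclobutyl on the shared core

A few compounds are considered here, and "the series" means these few. Any claim that something is new, unique, unknown or untested is made for them only; others in the source may bear on it.

Measured so far in a physicochemical assay for solubility, using the shake flask method, in simulated intestinal fluid, measured as kinetic solubility, with a stated time of 20 h, at pH 6.5 (on this read-out higher numbers stand for higher solubility and lower numbers for lower solubility), for three compounds
- compound 1 `O=C(O)c1ccc(Nc2cc3[nH]c(-c4cccc(C(F)(F)F)c4)nc3cn2)nc1` gives 6000 nM
- compound 2 `FC(F)(F)c1ccc(Nc2cc3[nH]c(C4CCOC4)nc3cn2)nc1` gives 180000 nM
- compound 3 `FC(F)(F)c1ccc(Nc2cc3[nH]c(C4CCOCC4)nc3cn2)nc1` gives 168000 nM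

Compound 3 at 168000 nM stands within the scatter of compound 2, and both lie well above compound 1 at 6000 nM on the numbers shown. The next structure is compound 4 `FC1(F)CC(c2nc3cnc(Nc4ccc(C(F)(F)F)cn4)cc3[nH]2)C1` and the change from compound 3 is 3,3-difluorocyclobutyl in place of oxan-4-yl on an aromatic carbon in which a ring of carbon only takes the place of a ring with a hetero atom. Going by the values given here, the one measured step at this place is a 1.1-fold lower number from compound 2 to compound 3 (0.03 log units; within the scatter) and it lies within the scatter. Among the compounds with values here, that step exchanges oxolan-3-yl for oxan-4-yl, so no measured step removes the ring oxygen, and the size of the new step remains uncertain. A moderately lower number is expected in this assay for this change. The expected step is a 2.8-fold lower number from compound 3 to compound 4 (0.45 log units; beyond the scatter) on this estimate. Compound 4 is estimated at 60000 nM with an expected range from 15000 nM to 170000 nM for now.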

Compound 4, solubility: 161000 nM
For compound 4 the middle estimate is 2.7-fold (0.43 log units) below the measured one; the measured number falls inside the stated range.
By their numbers in this assay, from the lowest: compound 1; then compounds 4, 3 and 2 (each within the scatter of the next).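

At this position, this assay now includes a change that removes the ring oxygen: 3,3-difluorocyclobutyl in place of oxan-4-yl gives (a 1.0-fold lower number from compound 3 to compound 4 (0.02 log units; within the scatter)) and in place of oxolan-3-yl gives (a 1.1-fold lower number from compound 2 to compound 4 (0.05 log units; within the scatter)). The earlier step changed only the oxygen-containing ring, whereas these two steps exchange a ring with one hydrogen-bond acceptor for a carbon-only ring with none, and neither step moves beyond the scatter. Across compound 2, compound 3 and compound 4, therefore, neither the ring oxygen nor the ring size separates the values on the shared core.

Still open, as far as these compounds go, is whether this flat picture extends to a piperidin-4-yl ring with its amine, a carboxylic acid, or an open alkyl chain on this aromatic carbon. From the compounds shown here alone, it is also open whether a carbon-only ring without fluorine behaves the same way. No measurement available here gives a reason for these values.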